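The compounds below may be only part of what the source reports. "The series", "measured", "known", "first", "only" and "open" are said of these compounds alone.

Measured in a functional assay (aorta) for inhibition, with Rattus norvegicus as the target; a higher number here means a weaker inhibitor, a lower number a stronger inhibitor:
- compound 1 `Cc1nsc(-c2ccc(N3CCN(c4cccc(Cl)c4)CC3)nn2)n1` gives 0.6 nM
- compound 2 `Cc1nsc(-c2ccc(N3CCN(c4cccc(C(F)(F)F)c4)CC3)nn2)n1` gives 0.3 nM
- compound 3 `Cc1nsc(-c2ccc(N3CCN(c4cccc(F)c4)CC3)nn2)n1` gives 6 nM

Compound 3 , at 6 nM, has the highest number of the three and is the weakest inhibitor in this small set. The two compounds that carry chloro and trifluoromethyl lie close together, with a 2.0-fold lower number from compound 1 to compound 2 (0.30 log units; within the scatter). Fluoro stands apart from both, with a 10-fold higher number from compound 1 to compound 3 (1.00 log units; beyond the scatter) and a 20-fold higher number from compound 2 to compound 3 (1.30 log units; beyond the scatter).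

The next change is cyano in place of fluoro on an aromatic carbon, which gives compound 4 `Cc1nsc(-c2ccc(N3CCN(c4cccc(C#N)c4)CC3)nn2)n1`. For the measured compounds named here, no compound with cyano has been measured yet, so the expectation rests on the two steps involving fluoro, read in reverse. Each of the two other groups gives a lower number than fluoro, so a lower number is expected in this assay here too. Going by the values given here, with only three compounds in hand, the size of the step is uncertain, and a step as large as a 20-fold higher number from compound 2 to compound 3 (1.30 log units; beyond the scatter) is not assumed.

This estimate means a 4.0-fold lower number from compound 3 to compound 4 (0.60 log units; beyond the scatter), an expected step that remains tentative. Compound 4 is expected at 1.5 nM, with an estimated range of 0.4 nM to 6 nM.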

Compound 4, half-maximal inhibitory concentration: 3 nM
Compound 4: middle estimate off by 2.0-fold (0.30 log units), on the low side; low and high end bracket the measured number.
By their numbers in this assay, from the lowest: compounds 2 and 1 (each within the scatter of the next); then compounds 4 and 3 (each within the scatter of the next).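

In this assay, the change from 3-fluorophenyl to 3-cyanophenyl, on an aromatic carbon meta to a large group, gives a 2.0-fold lower number from compound 3 to compound 4 (0.30 log units; within the scatter), so the hydrogen-bond acceptor that cyano brings and fluoro lacks comes with no step beyond the scatter. Cyano stands apart from the two other groups, with a 5.0-fold higher number from compound 1 to compound 4 (0.70 log units; beyond the scatter) and a 10-fold higher number from compound 2 to compound 4 (1.00 log units; beyond the scatter), and the four compounds at this position now read as two pairs, chloro with trifluoromethyl and cyano with fluoro, each pair lying within the scatter and the pairs separated by steps beyond it. No measurement of any property of these groups is available to account for this split into two pairs.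

The compounds shown leave open whether a methoxy group, an amine or a carboxylic acid on the same aromatic carbon would fall with either pair, and how an unsubstituted phenyl would read against all four. Also open, going by these compounds, is whether the two pairs would persist on a changed core or in a read-out other than this assay.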